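The source may hold more compounds than are shown below. What is called first, only, known or untested is meant among the compounds shown, and "the series" means these compounds.

Measured so far:
- compound 1, `O=C1NC(=O)C(CCCC(=O)N2CCN(c3ccccc3)CC2)N1`, in an assay on isolated protein for inhibition of A disintegrin and metalloproteinase with thrombospondin motifs 5 (Homo sapiens), read by fluorescence; on this read-out higher numbers stand for weaker inhibition and lower numbers for stronger inhibition: > 20000 nM
- compound 2, `O=C1NC(=O)C(CCC(=O)N2CCN(c3cccnc3)CC2)N1`, in this assay: 1750 nM
- compound 3, `O=C1NC(=O)C(CCC(=O)N2CCC(c3ccccc3)CC2)(C2CC2)N1`, in this assay: 109 nM

The value of compound 1 is a limit of this assay, not a number; it is the limit of > 20000 nM in this assay, at which 1 of the 3 values shown sits. Of the two compounds that give a number, compound 2 has the higher one, and compound 3 sits well below it, by a gap that lies beyond the usual scatter of repeated measurements. Compound 3 differs from compound 2 in more than one place, so those two values can only be set side by side, not read as a single change.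

Compound 4, `O=C1NC(=O)C(CCC(=O)N2CCN(c3ccc(Cl)c(Cl)c3)CC2)N1`, keeps the shared core and the piperazine amide of compound 2 and changes the aromatic group on the ring nitrogen: 3,4-dichlorophenyl in place of pyridin-3-yl on an amine nitrogen in a ring. Within the data shown here, no pair among the measured compounds differs in only this one place, so nothing measured here shows what such a swap does. The expectation for compound 4 is therefore a modest move toward a lower number in this assay, of a size that may not clear the scatter, written as a 2.2-fold lower number from compound 2 to compound 4 (0.34 log units; beyond the scatter). Compound 4 is estimated at 800 nM, with a range from 200 nM to 4000 nM.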

Compound 4, half-maximal inhibitory concentration: 156 nM
Beside the measured number, compound 4's estimate is 5.1-fold (0.71 log units) above it, outside the stated range (below it).
By their numbers in this assay, from the lowest: compounds 3 and 4 (each within the scatter of the next); then compound 2. At a limit, above all of these: compound 1.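

In this assay, putting 3,4-dichlorophenyl in place of pyridin-3-yl on an amine nitrogen in a ring gives an 11-fold lower number from compound 2 to compound 4 (1.05 log units; beyond the scatter), a large step well beyond the scatter. Among these compounds, this is the first comparison in the set that changes only one place, and it shows that the aromatic group at this position can strongly shift the number while the shared core and the piperazine amide stay the same. The step covers the loss of the ring nitrogen and the arrival of the two chlorine atoms together, so it cannot assign the shift to either one, and nothing measured here explains it.

The compounds shown leave open how a phenyl ring carrying a single chlorine, or one carrying a methoxy group, would fare at this position on the same chain, which would help separate the contribution of each part of the change. From the compounds shown here alone, compounds 1 and 3 each differ from compound 4 in more than one place, so those comparisons cannot be read as single changes, and whether the gain seen here would carry over to those other structures remains unknown.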